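Fluorine pattern shift on the chain-terminal aryl

The source may hold more compounds than are shown below. What is called first, only, known or untested is meant among the compounds shown, and "the series" means these compounds.

Compound 2 `Cc1c(CCCC(=O)O)c2cccc(/C=C/c3ccc(OCCCCc4c(F)cc(F)c(F)c4F)cc3)c2n1CC(=O)O` gives 0.3 10^-6 cm/s in a physicochemical assay for permeability, using PAMPA, with a stated time of 4 h, at pH 7.4, tested at 50 uM; a higher number here means that the compound crosses the layer faster, a lower number that the compound crosses the layer more slowly. Of the two numbers recorded in this assay it is the lower one; compound 3 `Cc1c(Cl)cccc1CCCCOc1ccc(C#Cc2cccc3c(CCCC(=O)O)c(C)n(CCC(=O)O)c23)cc1` gives 3 10^-6 cm/s, a gap described as beyond the scatter. Compound 1 `Cc1c(CCCC(=O)O)c2cccc(/C=C/c3ccc(OCCCCc4ccccc4)cc3)c2n1CC(=O)O` reaches only a limit of the assay, reported as < 0.05 10^-6 cm/s. Among the compounds with values here, the one measured step is an at least 6.0-fold higher number from compound 1 to compound 2 (0.77 log units; beyond the scatter); it is read against (the limit of < 0.05 10^-6 cm/s in this assay, at which 1 of the 3 values shown sits), so its true size is not known, only that it is at least modest.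

Compound 4 `Cc1c(CCCC(=O)O)c2cccc(/C=C/c3ccc(OCCCCc4cc(F)c(F)c(F)c4F)cc3)c2n1CC(=O)O` is the next member. Its difference from compound 2: 2,3,4,5-tetrafluorophenyl in place of 2,3,4,6-tetrafluorophenyl on a saturated chain carbon, four bonds along the chain from an oxygen on an aromatic ring. The two compounds have the same atoms, joined differently. Within the data shown here, no measured step speaks to a rearrangement of fluorines around a ring that already carries four of them; the step from compound 1 to compound 2 concerns adding the fluorines, not their pattern, and so bears on this change only indirectly. With no evidence for a directional effect, a step within the usual scatter is expected: no change at the digits printed from compound 2 to compound 4 (within the scatter).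

Compound 4 is therefore estimated at 0.3 10^-6 cm/s in this assay, with a range from 0.15 10^-6 cm/s to 0.6 10^-6 cm/s.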

Compound 4, apparent permeability: 0.3 10^-6 cm/s
For compound 4 middle estimate and measured number coincide at the digits printed; low and high end bracket the measured number.
By their numbers in this assay, from the lowest: compounds 2 and 4 (each within the scatter of the next); then compound 3. At a limit, below all of these: compound 1.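

In this assay, moving one fluorine around the ring gives no change at the digits printed from compound 2 to compound 4 (within the scatter), so at this place, on a saturated chain carbon, four bonds along the chain from an oxygen on an aromatic ring, 2,3,4,5-tetrafluorophenyl and 2,3,4,6-tetrafluorophenyl cannot be told apart. The second pattern also stands clear of phenyl, with an at least 6.0-fold higher number from compound 1 to compound 4 (0.77 log units; beyond the scatter), so the gain over phenyl is now seen with two tetrafluorophenyl patterns rather than with one. Compound 1 sits at a limit of the assay and not at a number, so both steps from it have a lower bound only: the limit of < 0.05 10^-6 cm/s in this assay, at which 1 of the 4 values shown sits.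

On these data alone, how the read-out runs with fewer or more fluorines on this ring remains open, for instance with 4-fluorophenyl, 2,4-difluorophenyl or pentafluorophenyl at the same place. Also open, as far as these compounds go, is whether the two tetrafluorophenyl patterns would still read alike on a longer chain, or on the core of compound 3 with its propanoic acid in place of the acetic acid of compound 2.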